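Thiophene for fluorophenyl on the triazole arm

A few compounds are considered here, and "the series" means these few. Any claim that something is new, unique, unknown or untested is made for them only; others in the source may bear on it.

Compound 3 `CCS[C@@H]1[C@H](SCC)[C@@H](Cn2cc(-c3ccc(F)cc3)nn2)O[C@H]1n1cc(C)c(=O)[nH]c1=O` gives 22700 nM in a functional assay on HepG2 cells (Homo sapiens) for cytotoxicity, read by MTT assay, with a stated time of 72 h; on this read-out higher numbers stand for an effect only at larger amounts of compound and lower numbers for an effect already at smaller amounts. Among the three measured compounds it shows the highest number, though compound 2 `CCS[C@@H]1[C@H](SCC)[C@@H](Cn2cc(-c3ccc(F)cc3)nn2)O[C@H]1n1ccc(=O)[nH]c1=O`, which gives 22600 nM in this assay, lies within the scatter of it; only compound 1 `CCS[C@@H]1[C@H](SCC)[C@@H](Cn2cc(-c3ccccc3)nn2)O[C@H]1n1ccc(=O)[nH]c1=O`, with 8380 nM in this assay, sits clearly lower, as the step of a 2.7-fold higher number from compound 1 to compound 2 (0.43 log units; beyond the scatter) shows. The step of a 1.0-fold higher number from compound 2 to compound 3 (0.00 log units; within the scatter) shows no movement on this read-out.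

Compound 4 `CCS[C@@H]1[C@H](SCC)[C@@H](Cn2cc(-c3cccs3)nn2)O[C@H]1n1cc(C)c(=O)[nH]c1=O` differs from compound 3 by thiophen-2-yl in place of 4-fluorophenyl on an aromatic carbon. Within the data shown here, no measured step exchanges the whole aromatic ring on the triazole, so the only step that bears on it is the one from compound 1 to compound 2, in which the fluorine alone moved the number by a modest amount; compound 4 loses that fluorine along with the six-membered ring. On this basis the expectation is a small shift, at most modest, toward a lower number, or none beyond the scatter, and the estimated step is a 1.5-fold lower number from compound 3 to compound 4 (0.18 log units; within the scatter). Compound 4 is therefore estimated to give 15000 nM in this assay, with a range from 6000 nM to 40000 nM.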

Compound 4, half-maximal effective concentration: >= 100000 nM
Compound 4: only a limit was reported; the forecaster's own chance of this, stated with the estimate: 10%; middle value at least 6.6-fold (0.82 log units) from the limit.
By their numbers in this assay, from the lowest: compound 1; then compounds 2 and 3 (each within the scatter of the next). At a limit, above all of these: compound 4.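

Compound 4 gives no number in this assay, only a limit of the assay: the limit of >= 100000 nM in this assay, at which 1 of the 4 values shown sits. Among these compounds, the exchange of 4-fluorophenyl for thiophen-2-yl on an aromatic carbon of the five-membered aromatic ring with 3 nitrogen gives an at least 4.4-fold higher number from compound 3 to compound 4 (0.64 log units; beyond the scatter), which shows for the first time that replacing the whole aromatic ring at this position moves the read-out, and not only a substituent on that ring. The only earlier change on this arm, a 2.7-fold higher number from compound 1 to compound 2 (0.43 log units; beyond the scatter), brought in a fluorine, whereas compound 4 carries no fluorine and still moves in the same direction, so among these compounds the number at this position does not follow the fluorine alone.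

With thiophen-2-yl as the only five-membered ring at this position, the compounds shown leave open whether the shift goes with the sulfur, with the ring size or with where the ring is attached, which a furan-2-yl, a thiophen-3-yl or a pyridin-2-yl group could help to separate. They also leave open how far the number lies past the limit, and whether thiophen-2-yl acts the same way on the core of compound 2, which lacks the methyl group.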